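Cytotoxicity of a Pyridylpiperazine Replacement for Phenoxy

The compounds below may be only part of what the source reports. "The series", "measured", "known", "first", "only" and "open" are said of these compounds alone.

Compound 1 `COc1ccc2[nH]c(C(=O)N3CC(=O)N(Cc4ccccc4)[C@@H](COc4ccccc4)C3)cc2c1` was tested in an ADME assay on Vero cells (Chlorocebus sabaeus) for cytotoxicity, with a stated time of 7 days; a higher number here means that more compound is tolerated, a lower number that less compound is tolerated. In this assay compound 1 gives only a limit, > 10000 nM. Its relatives tell the same story: compound 2 `COc1cccc(CN2C(=O)CN(C(=O)c3cc4cc(OC)ccc4[nH]3)C[C@@H]2COCc2ccccc2)c1` gives a limit of > 10000 nM in this assay. Compound 3 `COc1cccc(CN2C(=O)CN(C(=O)c3cc4cc(OC)ccc4[nH]3)C[C@@H]2c2ccccc2)c1` likewise gives a limit of > 10000 nM in this assay. For the measured compounds named here, the only single change measured, a step that the two limits leave unreadable from compound 2 to compound 3, cannot be read for size because of the limit of > 10000 nM in this assay, at which 3 of the 3 values shown sit. Compound 4 `COc1ccc2[nH]c(C(=O)N3CC(=O)N(Cc4ccccc4)[C@@H](CN4CCN(c5ccccn5)CC4)C3)cc2c1` differs from compound 1 by 4-(pyridin-2-yl)piperazin-1-yl in place of phenoxy on a saturated chain carbon bound to a saturated ring carbon. Going by the values given here, no measured step covers this change, so no direction beyond the scatter can be expected. Compound 4 is therefore expected to sit again at the limit, estimated at 15000 nM with a range from 5000 nM to 50000 nM. The expected step that the limit leaves unreadable from compound 1 to compound 4 is thus essentially none.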

Compound 4, half-maximal cytotoxic concentration: > 30000 nM
Compound 4: only a limit was reported (the forecaster's own chance of this, stated with the estimate: 80%); at least 2.0-fold (0.30 log units) between middle value and limit.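

Compound 1 and compound 4 each give only a limit in this assay, so the step between them cannot be read. The compounds shown leave open at what concentration any of them would harm the cells.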